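A Dichlorophenyl Variant of a Quinoxaline Spiro-Oxindole Series

The source may report more compounds than this note shows. Statements on the series, on what has been measured and on what is new or still open speak of the compounds shown alone.

Of the compounds shown here, three of one core have been tested in a functional assay on A549 cells (Homo sapiens) for antiproliferative activity, read by MTT assay, with a stated time of 48 h; a lower number here means a stronger inhibitor, a higher number a weaker inhibitor. Compound 1 `Cc1cccc(-n2nncc2CN2C(=O)C3(C(C#N)=C(N)Oc4c(N)cc5nc6ccccc6nc5c43)c3ccccc32)c1` gives 12300 nM in this assay. Compound 2 `Cc1ccc(-n2nncc2CN2C(=O)C3(C(C#N)=C(N)Oc4c(N)cc5nc6ccccc6nc5c43)c3ccccc32)cc1C` reaches only the limit of this assay, > 50000 nM. Compound 3 `CCc1cccc(CC)c1-n1nncc1CN1C(=O)C2(C(C#N)=C(N)Oc3c(N)cc4nc5ccccc5nc4c32)c2ccccc21` likewise reaches only the limit of this assay, > 50000 nM, so compound 3 stands at the weak end of what has been measured, together with one other value sitting at the same limit (the limit of > 50000 nM in this assay, at which 2 of the 3 values shown sit).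

Compound 4 `N#CC1=C(N)Oc2c(N)cc3nc4ccccc4nc3c2C12C(=O)N(Cc1cnnn1-c1cc(Cl)ccc1Cl)c1ccccc12` differs from compound 3 only at the aryl group on the triazole nitrogen: 2,5-dichlorophenyl in place of 2,6-diethylphenyl on an aromatic nitrogen.

Among the compounds with values here, two measured steps touch this position. The step of an at least 4.0-fold higher number from compound 1 to compound 3 (0.60 log units; beyond the scatter) shows that changing the phenyl substitution pattern moved the number beyond the scatter, while the step that the two limits leave unreadable from compound 2 to compound 3 cannot be read because both compounds sit at the limit. Within the data shown here, no measured compound carries a halogenated phenyl, so the direction of the change to a 2,5-dichlorophenyl is not fixed by the data. Compound 4 is therefore expected to remain weak, at about 40000 nM in this assay, within 8000 nM to 200000 nM, which means an expected step of an at least 1.2-fold lower number from compound 3 to compound 4 (0.09 log units; that floor lies within the scatter).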

Compound 4, half-maximal inhibitory concentration: 10900 nM
Estimate against measurement, compound 4: 3.7-fold (0.56 log units) above; measured number inside the range.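

The 2,5-dichlorophenyl group on the aromatic nitrogen brings the number back from the limit, with the change from 2,6-diethylphenyl giving an at least 4.5-fold lower number from compound 3 to compound 4 (0.66 log units; beyond the scatter) and the change from 3,4-dimethylphenyl giving an at least 4.5-fold lower number from compound 2 to compound 4 (0.66 log units; beyond the scatter). Both steps are floors rather than sizes, and compound 2 and compound 3 remain limits of the assay: the limit of > 50000 nM in this assay, at which 2 of the 4 values shown sit. Against the 3-methylphenyl group the change gives a 1.1-fold lower number from compound 1 to compound 4 (0.05 log units; within the scatter), so in this assay these two aryl groups cannot be told apart, and substitution on this ring does not in itself lead to the limit.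

On these data alone, what a single chlorine, a methoxy group or an unsubstituted phenyl would do at this position stays open. Also open, as far as these compounds go, is whether any group here can take the number clearly past that of compound 1, 12300 nM.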